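Working notes on three compounds in a cell cytotoxicity series

A few compounds are considered here, and "the series" means these few. Any claim that something is new, unique, unknown or untested is made for them only; others in the source may bear on it.

In a functional assay on PC-3 cells (Homo sapiens) for cytotoxicity, read by MTT assay (on this read-out higher numbers stand for weaker inhibition and lower numbers for stronger inhibition), compound 1 `Cc1nc(Nc2ccc(Cl)cc2)sc1C(=O)/C=C/c1ccccc1` gives 24600 nM. Compound 2 `COc1cc(/C=C/C(=O)c2sc(Nc3ccc(Cl)cc3)nc2C)cc(OC)c1OC` returns only a limit of the assay in this assay, namely > 25000 nM. Compound 2 therefore stands at the edge of what this assay reports, the point marked by the limit of > 25000 nM in this assay, at which 1 of the 2 values shown sits, and compound 1 sits close to that same edge; the two figures cannot be separated beyond the usual scatter, so no order between them can be read.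

Compound 3 `COc1cc(/C=C/C(=O)c2sc(Nc3ccccc3C)nc2C)cc(OC)c1OC` has not been measured. It differs from compound 2 by 2-methylphenyl in place of 4-chlorophenyl on a nitrogen on an aromatic ring. For the measured compounds named here, no measured pair shows this change, so its effect is unknown; the only anchors are two weak compounds. The step from compound 2 to compound 3 is expected to be a step that the limit leaves unreadable from compound 2 to compound 3, that is, nothing beyond the scatter in either direction. Compound 3 is estimated at 30000 nM, within a range from 10000 nM to 90000 nM, with a fair chance that this assay again reports only a limit.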

Compound 3, half-maximal inhibitory concentration: > 25000 nM
Compound 3 ended at the assay's limit; the forecaster's own chance of this, stated with the estimate: 55%; the middle value does not contradict the limit.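

No step can be read from compound 2 to compound 3, because in this assay both compounds return only a limit: the limit of > 25000 nM in this assay, at which 2 of the 3 values shown sit.

The compounds shown leave open what 2-methylphenyl in place of 4-chlorophenyl on a nitrogen on an aromatic ring does to cytotoxicity, in either direction.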